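The compounds below may be only part of what the source reports. "The series", "measured", "known", "first", "only" and "open" are said of these compounds alone.

Measured so far:
Compound 1 `Fc1cccc(-c2n[nH]cc2N2CCCNCC2)c1` gives 2540 nM in an assay on isolated protein for binding affinity to 5-hydroxytryptamine receptor 1D (Homo sapiens); a lower number here means a stronger inhibitor, a higher number a weaker inhibitor.
Compound 2 `COc1ccccc1-c1n[nH]cc1N1CCCNCC1` gives > 10000 nM in this assay, which is a limit of the assay rather than a number.

Compound 2 therefore stands at the limit of > 10000 nM in this assay, at which 1 of the 2 values shown sits, so only a limit is known for it. Compound 3 `c1ccc(-c2n[nH]cc2N2CCCNCC2)cc1` differs from compound 2 by hydrogen in place of methoxy on an aromatic carbon. Within the data shown here, no measured pair shows this same change, so the expected step rests only on the two values above and is estimated as an at least 3.3-fold lower number from compound 2 to compound 3 (0.52 log units; beyond the scatter), toward stronger binding. For compound 3 an inhibition constant of 3000 nM is expected, within 800 nM to 12000 nM.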

Compound 3, inhibition constant: > 10000 nM
Compound 3 ended at the assay's limit; the forecaster's own chance of this, stated with the estimate: 25%; middle value at least 3.3-fold (0.52 log units) away from the limit.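

Putting hydrogen in place of fluoro on an aromatic carbon gives an at least 3.9-fold higher number from compound 1 to compound 3 (0.59 log units; beyond the scatter) in this assay, so in this pair the fluoro compound binds more strongly than the compound without a substituent on that ring. Among these compounds, this is the first readable step, and it rests on a single pair. The step between methoxy and hydrogen cannot be read, since compound 2 and compound 3 both give only a limit of the assay: the limit of > 10000 nM in this assay, at which 2 of the 3 values shown sit.

On these data alone, whether methoxy and hydrogen truly differ therefore stays open. So does how a chloro group or an amine on the same aromatic carbon as the fluoro would compare with fluoro.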